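Shortening the fatty chain on a glycine-linked nucleoside

The compounds below may be only part of what the source reports. "The series", "measured", "known", "first", "only" and "open" are said of these compounds alone.

For the measured compounds named here, compound 2 `CC(C)CCCCCCCCCCCCC(=O)NCC(=O)N[C@@H]1[C@@H](O)[C@H](O)[C@@H](Nc2ncnc3[nH]cnc23)O[C@H]1CO` is the only compound with an actual number in a functional assay on L1210 cells (Mus musculus) for inhibition, read by thymidine incorporation, with a stated time of 3 h (on this read-out higher numbers stand for an effect only at larger amounts of compound and lower numbers for an effect already at smaller amounts), where compound 2 gives 1.6 uM. Compound 1 `CCOCCC(=O)NCC(=O)N[C@@H]1[C@@H](O)[C@H](O)[C@@H](Nc2ncnc3[nH]cnc23)O[C@H]1CO` reaches only a limit of the assay in this assay, > 1000 uM. Compound 3 `CCCCCCCCCCCC(=O)NCC(=O)N[C@@H]1[C@@H](O)[C@H](O)[C@@H](Nc2ncnc3[nH]cnc23)O[C@H]1CO` has not been measured yet. It differs from compound 2 by hydrogen in place of isobutyl on a saturated chain carbon, ten or more bonds along the chain from a carbonyl carbon. Going by the values given here, no step between measured compounds is known, so the expectation rests on the contrast alone: the step from compound 2 to compound 3 is expected to be a 5.0-fold higher number from compound 2 to compound 3 (0.70 log units; beyond the scatter), a loss somewhat beyond the usual scatter. Compound 3 is therefore estimated at 8 uM, between 2 uM and 40 uM.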

Compound 3, concentration for half-maximal effect: 20 uM
Compound 3: middle estimate off by 2.5-fold (0.40 log units), on the low side, and the stated range covers the measured number.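

In this assay, hydrogen in place of isobutyl on a saturated chain carbon gives a 13-fold higher number from compound 2 to compound 3 (1.10 log units; beyond the scatter), so a change at this place on the chain still matters. Nonyl in place of ethoxy, two bonds along the chain from a carbonyl carbon, gives an at least 50-fold lower number from compound 1 to compound 3 (1.69 log units; beyond the scatter), so compound 3 remains far ahead of compound 1. That second step is only a bound, since compound 1 stands at a limit of the assay: the limit of > 1000 uM in this assay, at which 1 of the 3 values shown sits.

On these data alone, whether a longer straight chain would match compound 2 stays open. So does the effect of an amine or a carboxylic acid at the far end of the chain.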